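A few compounds are considered here, and "the series" means these few. Any claim that something is new, unique, unknown or untested is made for them only; others in the source may bear on it.

Measured so far: compound 1 `CCCCCC(=O)Nc1ccc(S(=O)(=O)Oc2ccccc2C(C)C)cc1` with 6700 nM; compound 2 `CC(C)c1ccccc1OS(=O)(=O)c1ccc(NC(=O)CCCl)cc1` with 14000 nM.

In a functional assay on M21 cells (Homo sapiens) for antiproliferative activity, read by sulforhodamine B assay, with a stated time of 48 h (on this read-out higher numbers stand for weaker inhibition and lower numbers for stronger inhibition), compound 2 holds the highest of the two numbers. Within the data shown here, only one step is known in this assay: a 2.1-fold higher number from compound 1 to compound 2 (0.32 log units; beyond the scatter). Compound 3 `CCNC(=O)Nc1ccc(S(=O)(=O)Oc2ccccc2C(C)C)cc1` differs from compound 2 by ethylamino in place of 2-chloroethyl on a carbonyl carbon. The known step concerns a different change on the chain and offers no direct guide for this one, so no direction can be drawn from it. For compound 3 the expected step is a 1.3-fold lower number from compound 2 to compound 3 (0.10 log units; within the scatter), lying within the scatter. Compound 3 is accordingly estimated at 11000 nM, with a range from 3500 nM to 35000 nM.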

Compound 3, half-maximal inhibitory concentration: 4700 nM
For compound 3 the middle estimate is 2.3-fold (0.37 log units) above the measured one; the measured number falls inside the stated range.
By their numbers in this assay, from the lowest: compounds 3 and 1 (each within the scatter of the next); then compound 2.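

With ethylamino in place of 2-chloroethyl on the carbonyl carbon, this assay gives a 3.0-fold lower number from compound 2 to compound 3 (0.47 log units; beyond the scatter) and so shows that this carbonyl carbon responds to more than the chloro-for-propyl change at the chain end. Ethylamino in place of pentyl on the same carbon gives a 1.4-fold lower number from compound 1 to compound 3 (0.15 log units; within the scatter) and leaves that pair within the scatter, so only the 2-chloroethyl compound stands apart. No measured evidence accounts for these differences.

Still open, on these data alone, is how a longer chain on the nitrogen of the ethylamino group, or a terminal amine or carboxylic acid on that chain, would read in this assay.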